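A few compounds are considered here, and "the series" means these few. Any claim that something is new, unique, unknown or untested is made for them only; others in the source may bear on it.

Compound 3 `O=C(c1ccccc1)c1cccc(NC(=O)C2CCCN(C(=O)c3cc(C(F)(F)F)cc(C(F)(F)F)c3)C2)c1` is one of three amides built on a shared core. In an ADME assay on PC-3 cells (Homo sapiens) for cytotoxicity, read by WST assay, tested at 100 uM (a higher number here means more inhibition at the concentration tested (going by the name of the read-out), a lower number less inhibition), compound 3 gives 0%, level with compound 1 `O=C(Nc1cccc(-c2ccco2)c1)C1CCCN(C(=O)c2cc(C(F)(F)F)cc(C(F)(F)F)c2)C1`, which gives 0%, the two together being the lowest of the three numbers, while compound 2 `O=C(Nc1cccc([N+](=O)[O-])c1)C1CCCN(C(=O)c2cc(C(F)(F)F)cc(C(F)(F)F)c2)C1` gives 9%. Compound 4 `O=C(Nc1cccc(Cc2ccccc2)c1)C1CCCN(C(=O)c2cc(C(F)(F)F)cc(C(F)(F)F)c2)C1` differs from compound 3 as benzyl in place of benzoyl on an aromatic carbon. The measured steps at that aromatic carbon bear on this change: no change at the digits printed from compound 1 to compound 3 (within the scatter) and a number 9 percentage points lower from compound 2 to compound 3 (within the scatter), both within the scatter, as is a number 9 percentage points higher from compound 1 to compound 2 (within the scatter). Nothing measured here separates one group at that carbon from another beyond the scatter, so no step beyond the scatter is expected in this assay. Compound 4 is therefore expected to give 0%, within a range from 0% to 12%. The step of no change at the digits printed from compound 3 to compound 4 (within the scatter) is thus expected to stay within the scatter.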

Compound 4, a percentage reported as inhibition, at one concentration (the size of the read-out at that concentration, not a potency): 0%
For compound 4 middle estimate and measured number coincide at the digits printed; the measured number falls inside the stated range.
By their numbers in this assay, from the lowest: compounds 1, 3, 4 and 2 (each within the scatter of the next).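

With benzyl in place of benzoyl, this assay shows no change at the digits printed from compound 3 to compound 4 (within the scatter) and thus no separation when the carbonyl linking the aromatic ring to this aromatic carbon gives way to a carbon-only link. The other new steps agree, with no change at the digits printed from compound 1 to compound 4 (within the scatter) and a number 9 percentage points lower from compound 2 to compound 4 (within the scatter) both printed as within the scatter, so four groups at this position now cannot be told apart. No evidence here accounts for this result. The compounds leave open whether an amine or a carboxylic acid at this carbon would also stay within the scatter.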